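A few compounds are considered here, and "the series" means these few. Any claim that something is new, unique, unknown or untested is made for them only; others in the source may bear on it.

Measured in an ADME assay on microsomes (Homo sapiens) for metabolic stability; on this read-out lower numbers stand for a shorter-lived compound and higher numbers for a longer-lived compound:
- Compound 1 `Cc1c(Oc2ccccc2F)c(OC(C)C)nn1-c1ccc(C2CC2)cn1`: 0.0667 h
- Compound 2 `Cc1c(Oc2c(F)cccc2F)c(OC(C)C)nn1-c1ccc(C2CC2)cn1`: 0.1 h
- Compound 3 `Cc1c(Oc2c(F)cccc2F)c(OC(C)C)nn1-c1ncc(C2CC2)cc1F`: 0.45 h

Compound 2 stands at the low end together with compound 1, and compound 3 lies above both. Compound 4 `COc1ccc(-n2nc(OC(C)C)c(Oc3c(F)cccc3F)c2C)nn1` has 6-methoxypyridazin-3-yl in place of 5-cyclopropylpyridin-2-yl on an aromatic nitrogen.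

For the measured compounds named here, no measured step makes this same change. Fluoro in place of hydrogen on an aromatic carbon gave a 1.5-fold higher number from compound 1 to compound 2 (0.18 log units; within the scatter), on the side of the molecule that stays unchanged here. The same swap within the group now leaving gave a 4.5-fold higher number from compound 2 to compound 3 (0.65 log units; beyond the scatter). That second step is the nearer guide, so a modest rise is expected, with wide uncertainty. The expected step is a 3.0-fold higher number from compound 2 to compound 4 (0.48 log units; beyond the scatter). Compound 4 is estimated at 0.3 h, within an expected range from 0.1 h to 0.9 h.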

Compound 4, half-life: 0.367 h
The estimate for compound 4 lay 1.2-fold (0.09 log units) below the measured number; low and high end bracket the measured number.
By their numbers in this assay, from the lowest: compounds 1 and 2 (each within the scatter of the next); then compounds 4 and 3 (each within the scatter of the next).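

For the compounds shown here, a fluoro was the only earlier change on this ring, but here the whole group on the aromatic nitrogen is replaced. In this assay, 6-methoxypyridazin-3-yl in place of 5-cyclopropylpyridin-2-yl gives a 3.7-fold higher number from compound 2 to compound 4 (0.56 log units; beyond the scatter), so this position accepts a different ring and the loss of the cyclopropyl while the half-life still rises. Nothing measured here explains that rise. Still open, as far as these compounds go, is which part of the swap matters: the methoxy, the second ring nitrogen or the missing cyclopropyl. From the compounds shown here alone, how an amine or a carboxylic acid would behave on this ring is also open.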